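The compounds below may be only part of what the source reports. "The series", "measured", "known", "first", "only" and "open" are said of these compounds alone.

Compound 1 `COc1cc(N)c(Cl)cc1C(=O)NC1CCN(CCCCCO)CC1`, compound 2 `COc1cc(N)c(Cl)cc1C(=O)NC1CCN(CCCCCCCCN2C(=O)c3ccccc3C2=O)CC1`.

In an assay on HEK293 cells for displacement of a labelled ligand from 5-hydroxytryptamine receptor 4 (Homo sapiens), read by scintillation counting (a higher number here means a weaker inhibitor, a lower number a stronger inhibitor), compound 1 gives 63.1 nM and compound 2 gives 39.8 nM; the two numbers lie within the usual scatter of each other, so neither compound can be called the stronger binder. Compound 3 `COc1cc(N)c(Cl)cc1C(=O)NC1CCN(CCCCCCCCS(=O)(=O)O)CC1` differs from compound 2 by a group of 4 heavy atoms (3 oxygen, 1 sulfur; no ring) in place of a group of 11 heavy atoms (8 carbon, 1 nitrogen, 2 oxygen; one five-membered non-aromatic ring with 1 hetero atom, one six-membered aromatic ring of carbon only), on a saturated chain carbon, eight bonds along the chain from an amine nitrogen in a ring. Within the data shown here, no pair of measured compounds shows this exact change, so the only guide is compound 1, whose shorter chain ends in a hydroxyl and which gives 63.1 nM, suggesting that a small end group is tolerated. For compound 3 a modest weakening is expected, a 2.5-fold higher number from compound 2 to compound 3 (0.40 log units; beyond the scatter). Compound 3 is estimated at 100 nM, with a range from 30 nM to 400 nM.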

Compound 3, inhibition constant: 15800 nM
Estimate against measurement, compound 3: 160-fold (2.20 log units) below, and the stated range ends below it.
By their numbers in this assay, from the lowest: compounds 2 and 1 (each within the scatter of the next); then compound 3.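

The two earlier end groups, hydroxy and a larger two-ring group, gave values within the scatter of each other, so the end of the chain seemed open to change. The sulfo group shows that it is not: in this assay it brings a 400-fold higher number from compound 2 to compound 3 (2.60 log units; beyond the scatter), and 3-sulfopropyl in place of hydroxy brings a 250-fold higher number from compound 1 to compound 3 (2.40 log units; beyond the scatter). Nothing measured here bears on why binding falls so far. From the compounds shown here alone, whether a carboxylic acid or an amine at the chain end would cost as much remains open, as does the effect of a sulfo group on a shorter chain.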